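Acyl group exchange on the shared core

This account rests on a few compounds, and the source may have more. Where it says the series, first, only, none or still open, it means among the compounds named here.

Compound 2 `CC[C@H](N)C(=O)N1CCc2c(C)c3c(n2-c2ccc(C(N)=O)c(c2)N[C@@H](C)[C@H](C)C1)CC(C)(C)CC3=O` carries the higher of the two numbers measured in an in vitro ADME assay on microsomes (Mus musculus) for metabolic stability; on this read-out lower numbers stand for a shorter-lived compound and higher numbers for a longer-lived compound: compound 2 gives 0.383 h, whereas compound 1 `CC(=O)N1CCc2c(C)c3c(n2-c2ccc(C(N)=O)c(c2)N[C@@H](C)[C@H](C)C1)CC(C)(C)CC3=O` gives 0.0667 h. Among the measured compounds shown here, the only measured step, a 5.7-fold higher number from compound 1 to compound 2 (0.76 log units; beyond the scatter), concerns the same carbonyl carbon that is altered next. Compound 3 `Cc1c2c(n3c1CCN(C(=O)[C@@H](O)C(C)C)C[C@@H](C)[C@H](C)Nc1cc-3ccc1C(N)=O)CC(C)(C)CC2=O` differs from compound 2 at that place: 1-hydroxy-2-methylpropyl in place of 1-aminopropyl on a carbonyl carbon. For the measured compounds named here, no measured pair shows this particular exchange, so the step from compound 1 to compound 2 can only indicate that the group on this carbonyl carbon is able to move the half-life by a modest amount. It does not say in which direction the new group will move it, and compound 2 has no neighbour on the other side to set a ceiling. A modest change in either direction is therefore possible, and the expectation is placed between the two measured numbers rather than beyond them. Compound 3 is expected to show 0.25 h in this assay, with a range of 0.08 h to 0.8 h. This corresponds to an expected step of a 1.5-fold lower number from compound 2 to compound 3 (0.19 log units; within the scatter).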

Compound 3, half-life: 0.333 h
For compound 3 the middle estimate is 1.3-fold (0.12 log units) below the measured one, and the stated range covers the measured number.
By their numbers in this assay, from the lowest: compound 1; then compounds 3 and 2 (each within the scatter of the next).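

In this assay, the exchange on this carbonyl carbon gives a 1.2-fold lower number from compound 2 to compound 3 (0.06 log units; within the scatter), so 1-aminopropyl and 1-hydroxy-2-methylpropyl cannot be told apart on this read-out, although the group that enters holds oxygen where the group that leaves holds nitrogen. Measured against methyl, the new group gives a 5.0-fold higher number from compound 1 to compound 3 (0.70 log units; beyond the scatter), which means that a second, different group on this carbonyl carbon now stands clear of methyl, and the higher half-life is no longer seen with a nitrogen-bearing group alone. Nothing measured here bears on why these groups give the numbers they do.

The compounds shown leave open which part of the two groups goes with the step from methyl, and a plain ethyl or isopropyl group, carrying neither the amine nor the hydroxyl, would separate the carbon chain from the atom it bears. Also open, as far as these compounds go, is whether a carboxylic acid or a longer chain on the same carbonyl carbon would stay level with compound 2 and compound 3 or move the half-life further in either direction.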